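Extending the ether chain of compound 3

The source may report more compounds than this note shows. Statements on the series, on what has been measured and on what is new or still open speak of the compounds shown alone.

Measured compounds:
- compound 1, `CCOc1cc(=O)n(CCCO)c2c1CC(CC=C(C)C)C(C)(C)C2`: 66.5%
- compound 2, `CC(C)=CCC1Cc2c(OCCCNC(=O)c3ccco3)cc(=O)n(CCCO)c2CC1(C)C`: 2.1%
- compound 3, `CCOc1cc(=O)n(CCCO)c2c1CC(C/C=C(\C)CCC=C(C)C)C(C)(C)C2`: 67.8%

In a functional assay on PANC-1 cells (Homo sapiens) for inhibition, read by MTT assay, with a stated time of 24 h, tested at 10 uM (a higher number here means more inhibition at the concentration tested (going by the name of the read-out), a lower number less inhibition), compound 3 gives the highest of the three numbers; compound 1 stands nearest, a number 1.3 percentage points higher from compound 1 to compound 3 (within the scatter), and compound 2 stands furthest, its number far lower.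

Compound 4, `CC(C)=CCC/C(C)=C/COc1cc(=O)n(CCCO)c2c1CC(C/C=C(\C)CCC=C(C)C)C(C)(C)C2`, is not yet measured. It differs from compound 3 in one place: 2,6-dimethylhepta-1,5-dien-1-yl in place of methyl on a saturated chain carbon bound to an oxygen on an aromatic ring.

For the measured compounds named here, two measured steps bear on this. The step from compound 1 to compound 3 altered the chain on the other side of the core and gave a number 1.3 percentage points higher from compound 1 to compound 3 (within the scatter). The step from compound 1 to compound 2 added a group to the chain on the oxygen of the aromatic ring and gave a number 64.4 percentage points lower from compound 1 to compound 2 (beyond the scatter). The change in compound 4 also sits on that oxygen-bound chain, but what enters is a plain 2,6-dimethylhepta-1,5-dien-1-yl group with no donor or acceptor, unlike the group that entered in compound 2. The data therefore give no clean guide; a moderate decrease is expected, a number 19.8 percentage points lower from compound 3 to compound 4 (beyond the scatter), with wide uncertainty. Compound 4 is estimated at 48% (range 15% to 78%).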

Compound 4, a percentage reported as inhibition, at one concentration (the size of the read-out at that concentration, not a potency): 15.8%
The estimate for compound 4 lay 32.2 percentage points above the measured number; measured number inside the range.
By their numbers in this assay, from the lowest: compound 2; then compound 4; then compounds 1 and 3 (each within the scatter of the next).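

In this assay, replacing the ethyl on the ring-bound oxygen with 3,7-dimethylocta-2,6-dien-1-yl gave a number 52 percentage points lower from compound 3 to compound 4 (beyond the scatter), so a large loss at this position does not depend on the entering group carrying a ring, a hydrogen-bond donor or a hydrogen-bond acceptor. Before this result, the only change at the oxygen-bound chain was the amide-bearing furan group of a number 64.4 percentage points lower from compound 1 to compound 2 (beyond the scatter); the new step shows that a purely carbon chain with 2 double bonds outside aromatic rings can also lower the number beyond the scatter, while the chain extension on the other side of the core, a number 1.3 percentage points higher from compound 1 to compound 3 (within the scatter), stayed within it. No evidence at hand explains the loss seen with this ether chain.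

The compounds shown leave open how far the ether chain can grow from ethyl before the number falls, since a propyl or 3-methylbut-2-en-1-yl ether would fill that gap in length. They also do not settle whether a terminal amine or carboxylic acid on the long 3,7-dimethylocta-2,6-dien-1-yl chain would change the outcome in this assay.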